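The compounds below may be only part of what the source reports. "The series", "measured", "known", "first", "only" and "open" are said of these compounds alone.

Notes on the series around compound 1 `COc1cccc(OC)c1C(=O)Nc1c[nH]nc1C(=O)N[C@H]1CC[C@H](O)CC1`. In an ADME assay on MRC5 cells (Homo sapiens) for inhibition, with a stated time of 72 h (a lower number here means that less compound is needed, a higher number that more compound is needed for the effect), compound 1 gives 34000 nM, the higher of the two numbers recorded so far. Compound 3 `CO[C@H]1CC[C@H](NC(=O)c2n[nH]cc2NC(=O)c2ccccc2F)CC1` differs from compound 1 at several places; in this assay compound 3 gives 1000 nM, and the gap between these two numbers lies beyond the scatter. Compound 2 `COc1cccc(OC)c1C(=O)Nc1c[nH]nc1C(=O)NC1CCN(C(=O)OC(C)(C)C)CC1` returns only a limit in this assay, > 50000 nM, a value that marks (the limit of > 50000 nM in this assay, at which 1 of the 3 values shown sits).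

Compound 4 `COCCNC(=O)c1n[nH]cc1NC(=O)c1c(OC)cccc1OC` has not yet been measured in this assay. It differs from compound 1 in one place: 2-methoxyethyl in place of 4-hydroxycyclohexyl on an amide-type nitrogen. Within the data shown here, no measured pair in the set isolates this change, so the size of the step can be judged only from the spread of the numbers already in hand, which is wide. The step from compound 1 to compound 4 in this assay is expected to be small, about a 1.1-fold lower number from compound 1 to compound 4 (0.05 log units; within the scatter), within the scatter and in no clear direction. The estimate for compound 4 in this assay is 30000 nM, with a range from 8000 nM to 100000 nM. Compound 2 sits at the limit, and the chance that compound 4 also returns only a limit rather than a number is not negligible.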

Compound 4, half-maximal effective concentration: > 50000 nM
Compound 4: a limit, no number; the forecaster's own chance of this, stated with the estimate: 30%; at least 1.6-fold (0.22 log units) between middle value and limit.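

Swapping 4-hydroxycyclohexyl for 2-methoxyethyl on the amide-type nitrogen removes the six-membered ring, the hydrogen-bond donor and both defined stereocentres, and in this assay this change gives an at least 1.4-fold higher number from compound 1 to compound 4 (0.16 log units; that floor lies within the scatter); only a floor is available, so the real size of the step remains unknown and the floor itself does not clear the scatter. Compound 4 returns only a limit, > 50000 nM, so this position has now yielded a limit with an open chain as well. Among the compounds that share the rest of the structure of compound 1, compound 1 is the only one with a number, while compound 2 and compound 4 both stop at the limit: the limit of > 50000 nM in this assay, at which 2 of the 4 values shown sit.

The compounds shown do not separate the contributions of the ring, the hydroxyl and the stereocentres, and compound 3 differs from compound 1 at several places, so its value cannot be assigned to this position. Still open, as far as these compounds go, is how a plain cyclohexyl, a 2-hydroxyethyl chain or a substituent bearing an amine or a carboxylic acid on this nitrogen would read in this assay.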